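The source may hold more compounds than are shown below. What is called first, only, known or untested is meant among the compounds shown, and "the series" means these compounds.

Compound 1 `CC(C)CCn1c(Cn2c(=O)n(C3CC3)c3ccncc32)nc2nc(Cl)ccc21`: > 50000 nM
Compound 2 `CC(C)CCn1c(Cn2c(=O)n(C3CC3)c3ccncc32)nc2ncccc21`: > 100000 nM
Compound 3 `CC(C)CCn1c(Cn2c(=O)n(C3CC3)c3ccncc32)nc2cccnc21`: > 100000 nM

These three compounds share one core and were tested in an ADME assay on HeLa cells (Homo sapiens) for cytotoxicity, read by ATP content, with a stated time of 3 days; a higher number here means that more compound is tolerated, a lower number that less compound is tolerated. In this assay compound 1 gives > 50000 nM, which is a limit of the assay and not a number. Compound 2 gives > 100000 nM, also a limit. Compound 3 gives > 100000 nM, again a limit. Compound 1 therefore stands on a limit only, and the step that the two limits leave unreadable from compound 1 to compound 2 cannot be read; the limit of > 100000 nM in this assay, at which 2 of the 3 values shown sit, together with the limit of > 50000 nM in this assay, at which 1 of the 3 values shown sits, is all that the numbers say.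

Compound 4 `O=c1n(Cc2nc3nc(Cl)ccc3n2CCCCF)c2cnccc2n1C1CC1` differs from compound 1 by 2-fluoroethyl in place of isopropyl on a saturated chain carbon, two bonds along the chain from an aromatic nitrogen. Within the data shown here, no measured step touches this part of the molecule: the only measured step, a step that the two limits leave unreadable from compound 1 to compound 2, changes a different place and is itself unreadable. No step beyond the scatter is therefore expected in either direction. The estimated step is a step that the limit leaves unreadable from compound 1 to compound 4. Compound 4 is expected to give 80000 nM, with a range from 30000 nM to 200000 nM, and most likely only a limit will be reported.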

Compound 4, half-maximal cytotoxic concentration: > 50000 nM
Compound 4: a limit, no number; the forecaster's own chance of this, stated with the estimate: 85%; the middle value does not contradict the limit.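

Compound 1 and compound 4 each give only a limit of the assay and not a number, so no step between them can be read: the limit of > 50000 nM in this assay, at which 2 of the 4 values shown sit.

In this assay the compounds shown leave open whether 2-fluoroethyl in place of isopropyl changes how much compound is tolerated.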